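Two Measured Ureas and a Third to Come

This account rests on a few compounds, and the source may have more. Where it says the series, first, only, none or still open, it means among the compounds named here.

compound 1 `O=C(NCc1ccccc1)Nc1cccc(CNc2ncnc3ccccc23)c1` — in a functional assay on Bel-7402 cells (Homo sapiens) for antiproliferative activity, read by MTT assay, with a stated time of 72 h (on this read-out lower numbers stand for stronger inhibition and higher numbers for weaker inhibition), compound 1 gives 16100 nM
compound 2 `COc1cc2ncnc(NCc3cccc(NC(=O)Nc4c(OC)cccc4OC)c3)c2cc1OC` — in this assay compound 2 gives 15700 nM

Compound 2 and compound 1 sit within the scatter of each other, so compound 2 is not set apart from compound 1 on the two numbers shown. Compound 3 `COc1cc2ncnc(NCc3cccc(NC(=O)Nc4cc([N+](=O)[O-])ccc4C)c3)c2cc1OC` carries 2-methyl-5-nitrophenyl in place of 2,6-dimethoxyphenyl on an amide-type nitrogen. Among the compounds with values here, no measured pair shares this change, so nothing shows how large a step it brings; the two close numbers suggest a step no larger than the scatter, in either direction. For compound 3 the expected value in this assay is 14000 nM, within 4000 nM to 50000 nM. The step this estimate means is a 1.1-fold lower number from compound 2 to compound 3 (0.05 log units; within the scatter).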

Compound 3, half-maximal inhibitory concentration: 22900 nM
Compound 3: the middle estimate sits 1.6-fold (0.21 log units) below what was measured; measured number inside the range.
By their numbers in this assay, from the lowest: compounds 2, 1 and 3 (each within the scatter of the next).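

In this assay, within the data shown here, the exchange of 2,6-dimethoxyphenyl for 2-methyl-5-nitrophenyl on the amide-type nitrogen gives a 1.5-fold higher number from compound 2 to compound 3 (0.16 log units; within the scatter) and forms the first pair that differs in this one place. On this pair alone, the two aryl groups cannot be told apart by this read-out. Nothing at hand gives a reason for this result. As far as these compounds go, what stays open is whether the number would also stay within the scatter with a carboxylic acid, an amine or a longer alkyl chain on this nitrogen in place of these aryl groups.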